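Coumarin-3-carboxamide Cytotoxicity: From Cyclopropyl to Thiophene Hydrazone

The source may hold more compounds than are shown below. What is called first, only, known or untested is meant among the compounds shown, and "the series" means these compounds.

Compound 1 `CCOc1ccc2cc(C(=O)NCCO)c(=O)oc2c1`: > 100000 nM
Compound 2 `O=C(Nc1ccccc1)c1cc2ccc(OCc3ccccc3)cc2oc1=O`: > 100000 nM
Compound 3 `CCN(CC)c1ccc2cc(C(=O)NC3CC3)c(=O)oc2c1`: > 100000 nM

In a functional assay on HCT-116 cells (Homo sapiens) for cytotoxicity, read by MTT assay, with a stated time of 72 h (on this read-out lower numbers stand for stronger inhibition and higher numbers for weaker inhibition), compound 3 gives only a limit, > 100000 nM, and no number. Compound 1 likewise gives only a limit in this assay. The same holds for compound 2. Among the measured compounds shown here, all three measured values sit at the limit of > 100000 nM in this assay, at which 3 of the 3 values shown sit, so no compound stands apart from the others.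

Compound 4 `CCN(CC)c1ccc2cc(C(=O)N/N=C(/C)c3cccs3)c(=O)oc2c1` is not yet measured. It differs from compound 3 by a group of 8 heavy atoms (6 carbon, 1 nitrogen, 1 sulfur; one five-membered aromatic ring with 1 hetero atom) in place of a group of 3 heavy atoms (3 carbon; one three-membered non-aromatic ring of carbon only), on an amide-type nitrogen. For the measured compounds named here, no measured pair frames this change, so the expectation rests on compound 3 alone. Compound 4 is expected to give 60000 nM in this assay, with a range from 15000 nM to 200000 nM. The expected step of an at least 1.6-fold lower number from compound 3 to compound 4 (0.22 log units; that floor lies within the scatter) is thus small and uncertain; a further limit is quite possible.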

Compound 4, half-maximal inhibitory concentration: > 100000 nM
Compound 4: only a limit was reported; the forecaster's own chance of this, stated with the estimate: 60%; middle value at least 1.6-fold (0.22 log units) from the limit.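

In this assay compound 4 gives > 100000 nM, a limit and not a number. Compound 3 also gives only a limit, so no step between the two can be read: the limit of > 100000 nM in this assay, at which 4 of the 4 values shown sit.

The compounds shown leave open which change, if any, would give a measurable value.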